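The source may report more compounds than this note shows. Statements on the series, on what has been measured and on what is new or still open speak of the compounds shown alone.

Working notes on the series. In a functional assay on the whole organism for inhibition, with Rattus norvegicus as the target (a lower number here means that less compound is needed, a higher number that more compound is needed for the effect), compound 1 `Cc1cccc(N/N=C2\CCC(C)n3c2ncc(C(=O)O)c3=O)c1` gives 72.5 umol/kg. For compound 2 `Cc1ccc(N/N=C2\CCC(C)n3c2ncc(C(=O)O)c3=O)cc1` this assay reports only a limit, > 1000 umol/kg. For compound 3 `CC1CC/C(=N\Nc2cccc(C(F)(F)F)c2)c2ncc(C(=O)O)c(=O)n21` the result is likewise a limit, > 1000 umol/kg. The cores of compound 1 and compound 2 differ by 4-methylphenyl in place of 3-methylphenyl on an amine nitrogen, and this gives an at least 13-fold higher number from compound 1 to compound 2 (1.13 log units; beyond the scatter). The change trifluoromethyl in place of methyl on an aromatic carbon gives an at least 13-fold higher number from compound 1 to compound 3 (1.13 log units; beyond the scatter). Compound 4 `CC1CC/C(=N\Nc2ccc(C(F)(F)F)cc2)c2ncc(C(=O)O)c(=O)n21` carries the same kind of change as compound 3, namely (trifluoromethyl in place of methyl on an aromatic carbon), but here the group sits para to a large group rather than meta to a large group. The step from compound 2 to compound 4 cannot be placed precisely because of the limit of > 1000 umol/kg in this assay, at which 2 of the 3 values shown sit, compound 2 already standing there. Compound 4 is expected at a step that the limit leaves unreadable from compound 2 to compound 4, estimated near 2000 umol/kg, most likely again only a limit.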

Compound 4, dose for 50% inhibition: > 1000 umol/kg
Compound 4: no number, only a limit (the forecaster's own chance of this, stated with the estimate: 85%); the middle value is on the limit's open side.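

No new step can be read from compound 2 to compound 4, because both compounds report only a limit: the limit of > 1000 umol/kg in this assay, at which 3 of the 4 values shown sit. The compounds shown leave open what trifluoromethyl in place of methyl does para to a large group.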